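This account rests on a few compounds, and the source may have more. Where it says the series, first, only, none or still open, it means among the compounds named here.

Measured compounds:
compound 1, `Cc1ccc(/C=C2\S/C(=N\c3csc(-c4ccc(Cl)cc4)c3)NC2=O)cc1`, 900 nM
compound 2, `CN(C)c1ccc(/C=C2\S/C(=N\c3csc(-c4ccc(Cl)cc4)c3)NC2=O)cc1`, 800 nM
compound 3, `CN(C)c1ccc(/C=C2\S/C(=N\c3nc(-c4ccc(Cl)cc4)cs3)NC2=O)cc1`, 300 nM

All three were tested in a functional assay on MDA-MB-231 cells (Homo sapiens) for cytotoxicity, read by MTT assay, with a stated time of 72 h; on this read-out lower numbers stand for stronger inhibition and higher numbers for weaker inhibition. Compound 1 and compound 2 share one core and differ in a single group on the outer ring: methyl in place of dimethylamino on an aromatic carbon. This change gave a 1.1-fold higher number from compound 2 to compound 1 (0.05 log units; within the scatter), so in this assay compound 1 and compound 2 cannot be told apart.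

Compound 3 carries the dimethylamino group on the same kind of ring but on a different core; how the two cores differ is not broken down here. In this assay compound 3 gives the lowest of the three numbers, and its distance from compound 2 and from compound 1 is in each case beyond the scatter.

Compound 4, `Cc1ccc(/C=C2\S/C(=N\c3nc(-c4ccc(Cl)cc4)cs3)NC2=O)cc1`, is not yet measured. It is built on the core of compound 3 and differs from it by methyl in place of dimethylamino on an aromatic carbon. The surroundings of the change are described in the same words as for compound 2 and compound 1, so this is the same change, now on the other core. Because that change gave a 1.1-fold higher number from compound 2 to compound 1 (0.05 log units; within the scatter) on the first core, the expected step here is also small: a 1.1-fold higher number from compound 3 to compound 4 (0.04 log units; within the scatter). Compound 4 is therefore expected to give about 330 nM, most likely between 150 nM and 750 nM. This rests on a single earlier step, so the range is kept wide.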

Compound 4, half-maximal inhibitory concentration: 800 nM
For compound 4 the middle estimate is 2.4-fold (0.38 log units) below the measured one; the measured number lies above the stated range.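

In this assay, among the compounds shown here, exchanging 4-(dimethylamino)phenyl for 4-methylphenyl on the second core gave a 2.7-fold higher number from compound 3 to compound 4 (0.43 log units; beyond the scatter), a clear step, whereas the same exchange on the first core gave no step that could be told from scatter. Even so, the two results cannot be separated from each other, since each step carries its own measurement uncertainty: the same change on two cores in this assay, a 1.1-fold higher number (0.05 log units; within the scatter) from compound 2 to compound 1 and a 2.7-fold higher number (0.43 log units; beyond the scatter) from compound 3 to compound 4, 2.4-fold (0.37 log units) apart, within the scatter of two such steps This shows that the results fit a change that carries over from one core to the other, but it does not show that it carries over exactly, nor that the second core truly responds more strongly, and each core offers only one pair of compounds to judge from.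

The compounds shown leave open how other groups in the same place, such as methoxy, an unsubstituted hydrogen, a primary amine or a longer chain like ethyl, would behave on either core, and so whether the two cores really diverge for any such exchange. They also leave open whether the same picture would hold in any cell line other than the one used here.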